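A few compounds are considered here, and "the series" means these few. Any claim that something is new, unique, unknown or untested is made for them only; others in the source may bear on it.

Measured in an assay on isolated protein for inhibition of histone deacetylase 4 (Homo sapiens), with a stated time of 1 h; a lower number here means a stronger inhibitor, a higher number a weaker inhibitor:
compound 1 `O=C(COc1ccc2cc(/C=C3/SC(=O)NC3=O)ccc2c1)Nc1ccccc1` gives 2100 nM
compound 2 `O=C(COc1ccc2cc(/C=C3/SC(=O)NC3=O)ccc2c1)Nc1c(F)cc(F)cc1Br` gives 1100 nM
compound 3 `Cc1ccc(NC(=O)COc2ccc3cc(/C=C4/SC(=O)NC4=O)ccc3c2)cc1Cl` gives 1100 nM

Compound 1 carries the unsubstituted phenylcarbamoyl end and shows the highest number of the three, though a 1.9-fold lower number from compound 1 to compound 2 (0.28 log units; within the scatter) and a 1.9-fold lower number from compound 1 to compound 3 (0.28 log units; within the scatter) both stay within the scatter, so the three compounds are not separable in this assay. Compound 4 `O=C(COc1ccc2cc(/C=C3/SC(=O)NC3=O)ccc2c1)Nc1cccc(Cl)c1` differs from compound 1 as follows: chloro in place of hydrogen on an aromatic carbon Read one bond further out, this is phenyl to 3-chlorophenyl on an amide-type nitrogen, the same kind of change as in the two measured steps, each of which altered the substituents of that ring without moving the number beyond the scatter. A small step toward a lower number, or none at all, is therefore expected, a 1.4-fold lower number from compound 1 to compound 4 (0.15 log units; within the scatter). Compound 4 is estimated at 1500 nM, with a range of 700 nM to 3200 nM.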

Compound 4, half-maximal inhibitory concentration: 3800 nM
For compound 4 the middle estimate is 2.5-fold (0.40 log units) below the measured one; measured number outside the range, above it.
By their numbers in this assay, from the lowest: compounds 2, 3, 1 and 4 (each within the scatter of the next, the first and the last beyond it).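

Adding the chloro to the phenyl ring of compound 1 gives no separable change, a 1.8-fold higher number from compound 1 to compound 4 (0.26 log units; within the scatter), so this substitution alone does not account for the lower numbers of the other two compounds. Real separation in this assay appears only against compound 4: removing the methyl gives a 3.5-fold higher number from compound 3 to compound 4 (0.54 log units; beyond the scatter), and the ring exchange gives a 3.5-fold higher number from compound 2 to compound 4 (0.54 log units; beyond the scatter), so substituents on this ring can separate compounds. No evidence on the cause is at hand.

Open, on these data alone, is whether a methyl alone on this ring separates from compound 1. As far as these compounds go, an amine or a carboxylic acid on this ring also remains open.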